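A few compounds are considered here, and "the series" means these few. Any claim that something is new, unique, unknown or untested is made for them only; others in the source may bear on it.

Compound 1 `C=CCOc1ccc(C(=O)Nc2cccc(C)n2)cc1` gives 6000 nM in an in vitro assay on HEK-tsA201 cells for antagonist activity at Neuronal acetylcholine receptor; alpha4/beta2 (Homo sapiens), read by fluorescence and calcium flux; a higher number here means a weaker inhibitor, a lower number a stronger inhibitor.
Compound 2 `C=CCOc1ccc(C(=O)Nc2ccccn2)cc1` gives 19300 nM in this assay.
Compound 3 `CCCCNc1cccc(NC(=O)c2ccc(OCCC)cc2)n1` gives 54100 nM in this assay.

In this assay compound 3 stands at the highest of the three numbers, meaning it is the weakest inhibitor of those measured. Compound 2, at 19300 nM, is the nearest to it. Compound 1, at 6000 nM, is the furthest away, and both of those gaps are beyond the scatter.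

Compound 4 `C=CCOc1ccc(C(=O)Nc2cccc(NCCCC)n2)cc1` differs from compound 3 in one place: vinyl in place of ethyl on a saturated chain carbon bound to an oxygen on an aromatic ring. The only measured step among these compounds, a 3.2-fold higher number from compound 1 to compound 2 (0.51 log units; beyond the scatter), concerns a different position, the methyl on an aromatic carbon, and so says nothing about exchanging propoxy for allyloxy. Going by the values given here, compound 1 and compound 2 do carry the allyloxy group while compound 3 carries propoxy, but they also differ from compound 3 elsewhere, so no measured pair isolates this change. With nothing to point one way or the other, the step of a 1.1-fold lower number from compound 3 to compound 4 (0.03 log units; within the scatter) is expected to stay within the scatter. On that basis compound 4 is estimated at 50000 nM in this assay, with a range from 20000 nM to 130000 nM.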

Compound 4, half-maximal inhibitory concentration: 22400 nM
Compound 4: middle estimate off by 2.2-fold (0.35 log units), on the high side; the measured number falls inside the stated range.
By their numbers in this assay, from the lowest: compound 1; then compounds 2 and 4 (each within the scatter of the next); then compound 3.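

Exchanging propoxy for allyloxy, which at the saturated chain carbon bound to an oxygen on an aromatic ring means vinyl in place of ethyl, gives a 2.4-fold lower number from compound 3 to compound 4 (0.38 log units; beyond the scatter) in this assay; the two groups hold the same count of heavy atoms, so this position responds beyond the scatter to the double bond alone. With allyloxy held fixed, butylamino in place of hydrogen on an aromatic carbon gives a 1.2-fold higher number from compound 2 to compound 4 (0.06 log units; within the scatter) and leaves the two numbers indistinguishable, while butylamino in place of methyl gives a 3.7-fold higher number from compound 1 to compound 4 (0.57 log units; beyond the scatter) and so shows that compound 1 stands apart from compound 4 as well as from compound 2. No measurement shown here accounts for any of these steps.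

As far as these compounds go, it remains open whether the step from propoxy to allyloxy would keep its size with methyl or hydrogen in place of butylamino, and how a longer chain such as butoxy would read on that oxygen. Also open, from the compounds shown here alone, is how a smaller amine such as methylamino, or a hydroxyl group, would read on the aromatic carbon that carries butylamino.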